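The source may hold more compounds than are shown below. What is called first, only, known or untested is meant among the compounds shown, and "the series" means these compounds.

The two measured compounds share one core. Compound 1 `N#Cc1ccc(-c2nc(C(c3ccc(F)cc3)c3ccc(F)cc3)sc2CC(=O)O)cc1` gives 150 nM in an in vitro assay on HEK385-7 cells for displacement of a labelled ligand from prostaglandin D2 receptor 2 (Homo sapiens); on this read-out higher numbers stand for weaker inhibition and lower numbers for stronger inhibition. Compound 2 `N#Cc1cc(-c2nc(C(c3ccc(F)cc3)c3ccc(F)cc3)sc2CC(=O)O)ccc1F` gives 57 nM in this assay. Among the measured compounds shown here, the only step in hand is a 2.6-fold lower number from compound 1 to compound 2 (0.42 log units; beyond the scatter), so compound 2 has the lowest of the two numbers, with compound 1 as its nearest neighbour.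

Compound 3 `NS(=O)(=O)c1cccc(-c2nc(C(c3ccc(F)cc3)c3ccc(F)cc3)sc2CC(=O)O)c1` has not yet been measured. Its structure differs from compound 2 in one place: 3-sulfamoylphenyl in place of 3-cyano-4-fluorophenyl on an aromatic carbon. The group enters on an aromatic carbon of the five-membered aromatic ring with one nitrogen and one sulfur, next to the ring nitrogen and next to the ring atom that bears the carboxymethyl group.

For the measured compounds named here, no measured step changes the cyano-bearing phenyl into a sulfamoylphenyl, so nothing in the data speaks to this exchange directly. Going by the values given here, the one step known, from compound 1 to compound 2, alters only the pattern on that phenyl and is modest. The exchange to a sulfamoyl group is larger than that, and the direction is open. Compound 3 is therefore expected to give 150 nM in this assay, within 40 nM to 600 nM, which is an estimated step of a 2.6-fold higher number from compound 2 to compound 3 (0.42 log units; beyond the scatter).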

Compound 3, half-maximal inhibitory concentration: 140 nM
Compound 3: the middle estimate sits 1.1-fold (0.03 log units) above what was measured, within the range that was stated.
By their numbers in this assay, from the lowest: compound 2; then compounds 3 and 1 (each within the scatter of the next).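

In this assay, the exchange of 3-cyano-4-fluorophenyl for 3-sulfamoylphenyl on this aromatic carbon gives a 2.5-fold higher number from compound 2 to compound 3 (0.39 log units; beyond the scatter) as the first step shown in which the phenyl loses its nitrile and takes up a sulfamoyl group, and it runs opposite in direction to the step that led to compound 2. Set against 4-cyanophenyl, the same group gives a 1.1-fold lower number from compound 1 to compound 3 (0.03 log units; within the scatter) and so cannot be told apart from it, which shows that a nitrile on the phenyl is not required for a number of this size and leaves 3-cyano-4-fluorophenyl as the only one of the three groups that stands apart from the other two. Nothing at hand gives a reason for either step.

From the compounds shown here alone, compound 2 and compound 3 differ both in the fluorine and in nitrile against sulfamoyl, so how much of the step belongs to each stays open. An unsubstituted phenyl, a methylsulfonylphenyl or a carboxyphenyl at this position would show what each of these groups adds and whether the sulfamoyl nitrogen matters at all.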